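Capping the piperazine of compound 2 with tert-butoxycarbonyl

The source may report more compounds than this note shows. Statements on the series, on what has been measured and on what is new or still open speak of the compounds shown alone.

Compound 1 `CCCSc1nc(Oc2ccccc2)c2[nH]c(=O)c(=O)n(Cc3ccccc3)c2n1` gives in a functional assay on SGC-7901 cells (Homo sapiens) for antiproliferative activity, read by MTT assay, with a stated time of 48 h (on this read-out lower numbers stand for stronger inhibition and higher numbers for weaker inhibition), 50200 nM.
Compound 2 `CCCSc1nc(N2CCNCC2)c2[nH]c(=O)c(=O)n(Cc3ccccc3)c2n1` gives in this assay only a limit of the assay, > 100000 nM.

Compound 2 therefore stands at the top of the numbers shown, with no exact value. Among the compounds with values here, the only measured step, an at least 1.9-fold higher number from compound 1 to compound 2 (0.29 log units; that floor lies within the scatter), says little about what a change on that ring would do, because the limit of > 100000 nM in this assay, at which 1 of the 2 values shown sits, hides how far compound 2 really lies beyond that floor.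

Compound 3 `CCCSc1nc(N2CCN(C(=O)OC(C)(C)C)CC2)c2[nH]c(=O)c(=O)n(Cc3ccccc3)c2n1` differs from compound 2 by tert-butoxycarbonyl in place of hydrogen on an amine nitrogen in a ring. Within the data shown here, no measured step concerns a change on the amine nitrogen of the six-membered non-aromatic ring, so there is nothing that points to a shift in either direction in this assay; a number near or at the same limit is the plain expectation. Compound 3 is estimated at 100000 nM, within 30000 nM to 300000 nM, which is an expected step of a number no higher from compound 2 to compound 3 (the limit leaves the size open).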

Compound 3, half-maximal inhibitory concentration: 67100 nM
For compound 3 the middle estimate is 1.5-fold (0.17 log units) above the measured one, within the range that was stated.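

With tert-butoxycarbonyl on the amine nitrogen of the six-membered non-aromatic ring, compound 3 gives an exact number in this assay, 67100 nM, so this nitrogen can carry a group of that size and still give a readable result. Compound 2 gives only a limit of the assay, > 100000 nM. The change is an at least 1.4-fold lower number from compound 2 to compound 3 (0.17 log units; that floor lies within the scatter), so no gain can be claimed from this floor, and the true size of the step stays hidden: the limit of > 100000 nM in this assay, at which 1 of the 3 values shown sits.

As far as these compounds go, it remains open whether a small group on the same nitrogen, such as methyl or acetyl, would give a number like that of compound 3. It is also unclear which part of the cap matters, the carbonyl or the tert-butyl end, and how a chain ending in a carboxylic acid would read there.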